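Hydroxy for Carbamoyl on a Vinyl Sulfone Core

This account rests on a few compounds, and the source may have more. Where it says the series, first, only, none or still open, it means among the compounds named here.

Compound 1 `NC(=O)c1ccc2c(c1)S(=O)(=O)C=C2` is the weakest of the three measured compounds in a functional assay on CCRF-CEM cells (Homo sapiens) for cytotoxicity, read by MTT assay, with a stated time of 72 h (a higher number here means a weaker inhibitor of growth, a lower number a stronger inhibitor of growth), giving 3550 nM. Compound 2 `CCCCNC(=O)c1ccc2c(c1)S(=O)(=O)C=C2` gives 280 nM in this assay, and compound 3 `CN(Cc1ccccc1)S(=O)(=O)c1ccc2c(c1)S(=O)(=O)C=C2` gives 630 nM. For the measured compounds named here, the single measured step, a 13-fold lower number from compound 1 to compound 2 (1.10 log units; beyond the scatter), concerns the amide nitrogen and not the aromatic carbon itself; no measured pair exchanges the carbamoyl group for another group, so there is no direct precedent for the change at hand.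

Compound 4 `O=S1(=O)C=Cc2ccc(O)cc21` differs from compound 1 in one place: hydroxy in place of carbamoyl on an aromatic carbon. What the data show is that the two compounds with more elaborate groups at that position, compound 2 and compound 3, both give lower numbers than compound 1, whereas compound 4 carries a smaller group there. The expectation for this step is therefore uncertain and no step beyond the scatter is claimed. The number for compound 4 in this assay is estimated at 4500 nM, within a range from 1200 nM to 16000 nM, which corresponds to an expected step of a 1.3-fold higher number from compound 1 to compound 4 (0.10 log units; within the scatter).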

Compound 4, concentration for 50% growth inhibition: 19200 nM
Estimate against measurement, compound 4: 4.3-fold (0.63 log units) below; the measured number lies above the stated range.
By their numbers in this assay, from the lowest: compound 2; then compound 3; then compound 1; then compound 4.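

In this assay, for the compounds shown here, the exchange of carbamoyl for hydroxy is the first measured change on the aromatic carbon itself, and it gives a 5.4-fold higher number from compound 1 to compound 4 (0.73 log units; beyond the scatter), so the group on this carbon does bear on the number. The direction is opposite to that of the earlier step on the amide nitrogen, a 13-fold lower number from compound 1 to compound 2 (1.10 log units; beyond the scatter), which shows that the carbamoyl group of compound 1 can be changed with either outcome, depending on where the change is made. Nothing in the data given accounts for the higher number of compound 4.

On these data alone, it remains open whether an amine, a carboxylic acid or a methoxy group on the same aromatic carbon would give a number nearer to that of compound 1 or of compound 4. As far as these compounds go, it is also open whether a longer chain on the oxygen of compound 4 would lower its number as butyl did on the amide nitrogen.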